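A pyrazole in place of a triazole on a hydroxylated amide

The source may hold more compounds than are shown below. What is called first, only, known or untested is meant among the compounds shown, and "the series" means these compounds.

Three amides share a hydroxylated five-membered ring attached to a carbonyl carbon. Compound 1 `O=C(Nc1cccc(C(F)(F)F)c1)c1nsnc1O` carries a single trifluoromethyl group on its aniline, while compound 2 `Cn1nnc(O)c1C(=O)Nc1cc(C(F)(F)F)cc(C(F)(F)F)c1` and compound 3 `O=C(Nc1cc(C(F)(F)F)cc(C(F)(F)F)c1)c1n[nH]nc1O` each carry two. In an assay on isolated protein for inhibition of mitogen-activated protein kinase kinase kinase 14 (Homo sapiens), read by ADP-Glo, with a stated time of 60 min, in the presence of a further agent that is not named here (a lower number here means a stronger inhibitor, a higher number a weaker inhibitor), compound 1 gives > 100000 nM, which is a limit of the assay and not a number. Compound 2 likewise gives only a limit, > 100000 nM. Compound 3 also stops at a limit, > 100000 nM. The step from compound 2 to compound 3 is a step that the two limits leave unreadable from compound 2 to compound 3; the two limits leave its size unreadable. Compound 2 thus stands at the limit in this assay, as do both other compounds shown (the limit of > 100000 nM in this assay, at which 3 of the 3 values shown sit).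

Compound 4 `Cn1cc(C(=O)Nc2cc(C(F)(F)F)cc(C(F)(F)F)c2)c(O)n1` has not yet been measured. It differs from compound 2 in one place: 3-hydroxy-1-methyl-1H-pyrazol-4-yl in place of 4-hydroxy-1-methyl-1H-1,2,3-triazol-5-yl on a carbonyl carbon. Within the data shown here, the only measured step that exchanges the hydroxylated ring, from compound 2 to compound 3, is unreadable, so no measured step sets a size or direction for this change. The chemist therefore expects no step beyond the scatter in this assay, a number no higher from compound 2 to compound 4 (the limit leaves the size open). For compound 4 the expected value is 100000 nM, with a range from 30000 nM to 300000 nM, and most probably the assay will again report only a limit.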

Compound 4, half-maximal inhibitory concentration: > 100000 nM
Compound 4 gave a limit, no number; the forecaster's own chance of this, stated with the estimate: 80%; the middle value sits exactly at the limit.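

In this assay compound 4 gives > 100000 nM, which is a limit of the assay and not a number. Its steps from compound 2 and compound 3 therefore cannot be read, as all the values are limits: the limit of > 100000 nM in this assay, at which 4 of the 4 values shown sit.

The compounds shown leave open how strongly any of them inhibits, and whether exchanging the hydroxylated ring changes that at all.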